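The compounds below may be only part of what the source reports. "The series", "measured", "known", "first", "only" and "open" are said of these compounds alone.

Values in an ADME assay on L02 cells (Homo sapiens) for cytotoxicity, read by MTT assay, with a stated time of 24 h; on this read-out higher numbers stand for weaker inhibition and lower numbers for stronger inhibition:
- Compound 1 `O=C1/C(=C/c2ccccc2F)CN(S(=O)(=O)c2ccc(F)cc2)C/C1=C\c1ccccc1F`: 19100 nM
- Compound 2 `COc1cc(/C=C2\CN(S(=O)(=O)c3ccc(F)cc3)C/C(=C\c3cc(OC)c(OC)c(OC)c3)C2=O)cc(OC)c1OC`: 12100 nM
- Compound 3 `N#Cc1ccc(/C=C2\CN(S(=O)(=O)c3ccc(F)cc3)C/C(=C\c3ccccc3F)C2=O)cc1`: 21900 nM

Compound 3, at 21900 nM, cannot be told apart from the other two compounds, as its value lies within the scatter of both. Compound 4 `COc1cc(/C=C2\CN(S(=O)(=O)c3ccc(F)cc3)C/C(=C\c3ccccc3F)C2=O)cc(OC)c1OC` carries 3,4,5-trimethoxyphenyl in place of the 4-cyanophenyl of compound 3, on a double-bonded chain carbon bound to a double-bonded ring carbon: 3,4,5-trimethoxyphenyl in place of 4-cyanophenyl on a double-bonded chain carbon bound to a double-bonded ring carbon. Its 2-fluorophenyl group stays as it is.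

Among the compounds with values here, only one measured step bears directly on this place. Going a 1.1-fold higher number from compound 1 to compound 3 (0.06 log units; within the scatter), the exchange of 2-fluorophenyl for 4-cyanophenyl stayed within the scatter. Within the data shown here, no step yet shows 3,4,5-trimethoxyphenyl entering alone. However, compound 2, which has that group at both such places, gives 12100 nM, while compound 1, which has 2-fluorophenyl at both, gives 19100 nM. Compound 4 has one of each, so a value in the region of these two is expected. No step beyond the scatter is therefore expected in this assay, and the estimated step is a 1.5-fold lower number from compound 3 to compound 4 (0.16 log units; within the scatter). For compound 4 the estimated value is 15000 nM, with an expected range of 8500 nM to 26000 nM.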

Compound 4, half-maximal inhibitory concentration: 17600 nM
Compound 4: the middle estimate sits 1.2-fold (0.07 log units) below what was measured, within the range that was stated.
By their numbers in this assay, from the lowest: compounds 2, 4, 1 and 3 (each within the scatter of the next).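

Within the data shown here, measured directly in this assay, the exchange of 4-cyanophenyl for 3,4,5-trimethoxyphenyl on a double-bonded chain carbon bound to a double-bonded ring carbon gives a 1.2-fold lower number from compound 3 to compound 4 (0.09 log units; within the scatter) and so leaves the number within the scatter, which the earlier compounds could only suggest. None of them showed 3,4,5-trimethoxyphenyl entering alone. The same holds for the two further exchanges now readable at such a place, with a 1.1-fold lower number from compound 1 to compound 4 (0.04 log units; within the scatter) for 3,4,5-trimethoxyphenyl replacing 2-fluorophenyl and a 1.5-fold higher number from compound 2 to compound 4 (0.16 log units; within the scatter) for 2-fluorophenyl replacing 3,4,5-trimethoxyphenyl, so among these compounds 2-fluorophenyl, 4-cyanophenyl and 3,4,5-trimethoxyphenyl cannot be told apart at this place in this assay and none of the exchanges stands out. Nothing measured here gives a reason for this lack of separation.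

All the groups compared at this place are substituted phenyl rings, so the compounds shown leave open whether a group of another kind there, such as an amine, a carboxylic acid or a longer chain, would move the number beyond the scatter. As far as these compounds go, they also keep the rest of the shared core unchanged, so what an exchange elsewhere on it would do in this assay stays open.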